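The source may report more compounds than this note shows. Statements on the series, on what has been measured and on what is new or still open speak of the compounds shown alone.

The compounds measured so far:

Compound 1, `Nc1scc(CN2CCN(c3cccnc3)CC2)c1C(=O)c1ccc(Cl)cc1`, gives 0%.
Compound 2, `Nc1scc(CN2CCC(c3ccc(Cl)cc3)CC2)c1C(=O)c1ccc(Cl)cc1`, gives 6%.
Compound 3, `Nc1scc(CN2CCN(c3cccc(F)c3)CC2)c1C(=O)c1cccc(C(F)(F)F)c1`, gives 0%.

All three numbers come from an assay on CHO cells for displacement of a labelled ligand from adenosine receptor A3 (Homo sapiens), read by scintillation counting, with a stated time of 120 min, tested at 10 uM; a higher number here means more inhibition at the concentration tested (going by the name of the read-out), a lower number less inhibition. Compound 1 stands level with compound 3 at the digits shown, and these two share the lowest reading of the set; compound 3 is thus the nearest to compound 1, with no change at the digits shown. Compound 2 is the furthest from compound 1, yet its value still lies within the usual scatter of the measurement, so the three readings cannot be told apart with confidence. Going by the values given here, in short, every compound measured in this assay so far shows little or no displacement of the labelled ligand at the single concentration tested.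

Compound 4, `Nc1scc(CN2CCN(CCCc3ccc(Cl)cc3)CC2)c1C(=O)c1ccc(Cl)cc1`, has not yet been measured. It differs from compound 1 in a single place: 3-(4-chlorophenyl)propyl in place of pyridin-3-yl on an amine nitrogen in a ring. The amine nitrogen in the ring now carries 3-(4-chlorophenyl)propyl where compound 1 carries pyridin-3-yl. Among the compounds with values here, no measured pair among the three compounds shows a change of this kind, so the data give no direction for it. The account therefore expects a step of a number 5 percentage points higher from compound 1 to compound 4 (within the scatter) for compound 4, that is, none beyond the scatter. Compound 4 is expected to give about 5% in this assay, within a range from -10% to 25%.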

Compound 4, a percentage reported as inhibition, at one concentration (the size of the read-out at that concentration, not a potency): 0%
Estimate against measurement, compound 4: 5 percentage points above; measured number inside the range.
By their numbers in this assay, from the lowest: compounds 1, 3, 4 and 2 (each within the scatter of the next).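

Going by these compounds alone, on the amine nitrogen in the ring, putting 3-(4-chlorophenyl)propyl in place of pyridin-3-yl gives no change at the digits printed from compound 1 to compound 4 (within the scatter) in this assay and is the first change in one place that can be read in this set. It shows that this position accepts a much larger substituent, 10 heavy atoms instead of 6 with a carbon-only aromatic ring and a propyl chain, without the reading leaving the level of little or no displacement; since compound 1 already stands at the bottom of the scale, however, the step could not have shown a loss, only a gain, and none appeared. No measured property of these compounds bears on this result, and the flat reading remains unexplained.

The compounds shown leave open whether any group on this nitrogen can lift the reading beyond the scatter, for instance a benzyl group, an acyl group such as acetyl, or a propyl chain ending in a carboxylic acid or a primary amine. They also leave open whether the same change would show any step on a compound with a reading well above zero, since this pair starts from none.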